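The source may report more compounds than this note shows. Statements on the series, on what has been measured and on what is new or still open speak of the compounds shown alone.

Three compounds share one core and differ only at the acid-bearing end of the molecule. Compound 1 `CC(C)c1onc(-c2c(Cl)cccc2Cl)c1COc1ccc(CNc2ccc(CC(=O)O)cc2)cc1` gives 1600 nM in an assay on HEK-293T cells for activation of Bile acid receptor (Homo sapiens), read by a luciferase reporter, with a stated time of 14 h; a higher number here means that more compound is needed for the effect, a lower number that less compound is needed. Compound 2 `CC(C)c1onc(-c2c(Cl)cccc2Cl)c1COc1ccc(CCCC(=O)O)cc1` gives 6000 nM in this assay, the highest of the three numbers, so more of it is needed than of either neighbour. Compound 3 `Cc1cc(NCc2ccc(OCc3c(-c4c(Cl)cccc4Cl)noc3C(C)C)cc2)ccc1CC(=O)O` gives 1200 nM in this assay. The measured steps are a 3.8-fold higher number from compound 1 to compound 2 (0.57 log units; beyond the scatter), a 1.3-fold lower number from compound 1 to compound 3 (0.12 log units; within the scatter) and a 5.0-fold lower number from compound 2 to compound 3 (0.70 log units; beyond the scatter).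

Compound 4 `CC(C)c1onc(-c2ccccc2)c1COc1ccc(CCCC(=O)O)cc1` has not yet been measured. It differs from compound 2 by phenyl in place of 2,6-dichlorophenyl on an aromatic carbon. Going by the values given here, none of the measured steps concerns that part of the structure; all three change the acid-bearing end, so no measured step bears directly on this change, and the expectation must lean mainly on compound 2 itself. The expectation is a step of a 2.0-fold higher number from compound 2 to compound 4 (0.30 log units; within the scatter), modest and toward a higher number, with wide uncertainty. Compound 4 is expected to give 12000 nM in this assay, within a range from 3000 nM to 50000 nM.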

Compound 4, half-maximal effective concentration: 31000 nM
Beside the measured number, compound 4's estimate is 2.6-fold (0.41 log units) below it; measured number inside the range.
By their numbers in this assay, from the lowest: compounds 3 and 1 (each within the scatter of the next); then compound 2; then compound 4.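

Replacing 2,6-dichlorophenyl with plain phenyl, with the acid-bearing end left as it is, gives a 5.2-fold higher number from compound 2 to compound 4 (0.71 log units; beyond the scatter) in this assay. Going by these compounds alone, this is the first measured change away from the acid-bearing end, and it shows that the group on the aromatic carbon next to the ring nitrogen also affects how much compound is needed: without the two chlorine atoms, more is required. No measurement shown here accounts for this shift.

The compounds shown leave open whether a single chlorine, as in 2-chlorophenyl, would be enough, and whether other atoms or groups, such as fluorine or methyl, could take the place of the chlorines. They also leave open whether the same swap would produce a similar step on the longer acid-bearing ends of compound 1 and compound 3.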